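The source may hold more compounds than are shown below. What is called first, only, known or untested is meant among the compounds shown, and "the series" means these compounds.

Notes on the series in an ADME assay on microsomes from liver (Homo sapiens), read by LC-MS, using NADPH, with a stated time of 30 min, tested at 1 uM; on this read-out lower numbers stand for a less stable compound and higher numbers for a more stable compound

Compound 1 `C[C@H](Nc1ncnc2[nH]cnc12)c1cc2ccccn2c(=O)c1-c1ccccc1` gives 100% in this assay. Compound 2 `Cc1cccc2cc([C@H](C)Nc3ncnc4[nH]cnc34)c(-c3ccccc3)c(=O)n12` gives 70%. The difference between the two is methyl in place of hydrogen on an aromatic carbon and the step it made is a number 30 percentage points lower from compound 1 to compound 2 (beyond the scatter).

Compound 3 `C[C@H](Nc1nc(N)nc(N)c1C#N)c1cc2ccc(F)cn2c(=O)c1-c1ccccc1` gives 87%. The difference between the core of compound 3 and the core of compound 1 is not broken down here; the numbers show compound 3 somewhat lower than compound 1 and higher than compound 2.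

Compound 4 `Cc1cccc(-c2c([C@H](C)Nc3nc(N)nc(N)c3C#N)cc3ccc(F)cn3c2=O)c1` has not yet been measured in this assay. It differs from compound 3 by methyl in place of hydrogen on an aromatic carbon. This is the same kind of change as from compound 1 to compound 2, but the place is not the same: in compound 2 the methyl enters on an aromatic carbon of a six-membered aromatic ring with one nitrogen, part of a fused or bridged system of two rings, next to the ring nitrogen, ortho to a fused ring and meta to a fused ring; in compound 4 it enters on an aromatic carbon of a six-membered aromatic ring of carbon only, meta to a large group, the phenyl becoming 3-methylphenyl.

Among the measured compounds shown here, the expected step is a number 17 percentage points lower from compound 3 to compound 4 (beyond the scatter), set beside the earlier one on the grounds that the only measured instance of this kind of change, from compound 1 to compound 2, gave a number 30 percentage points lower from compound 1 to compound 2 (beyond the scatter), while the different place leaves the size uncertain. For compound 4 the estimate is 70%, expected to fall between 48% and 90%.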

Compound 4, percent of the compound remaining: 89%
The estimate for compound 4 lay 19 percentage points below the measured number; the measured number falls inside the stated range.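

In this assay, methyl in place of hydrogen on an aromatic carbon gave a number 2 percentage points higher from compound 3 to compound 4 (within the scatter), whereas the earlier instance of this kind of change gave a number 30 percentage points lower from compound 1 to compound 2 (beyond the scatter). The step therefore does not carry over in size from one core to the other, and the step on the core of compound 1 gives no safe guide to the step on the core of compound 3: the same change on two cores in this assay, a number 30 percentage points lower (beyond the scatter) from compound 1 to compound 2 and a number 2 percentage points higher (within the scatter) from compound 3 to compound 4, 32 percentage points apart, beyond the scatter of two such steps. This does not show that the core alone sets the size of the step, since the methyl enters a different place in each pair, on a six-membered aromatic ring with one nitrogen in compound 2 and on a six-membered aromatic ring of carbon only in compound 4, so core and place cannot be separated with these two pairs, and neither pair says anything about the cause of the gap.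

Open, as far as these compounds go, is how the phenyl to 3-methylphenyl change reads on the core of compound 1, and how a methyl in the place it holds in compound 2 reads on the core of compound 3, either of which would begin to separate core from place. Also open, from the compounds shown here alone, is how this assay responds on either core when the group entering on the phenyl is something other than methyl, such as an ethyl, an amine or a carboxylic acid.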